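The source may report more compounds than this note shows. Statements on the series, on what has been measured and on what is new or still open speak of the compounds shown alone.

Within the data shown here, in a functional assay on MDA-MB-231 cells (Homo sapiens) for inhibition, read by CCK-8 assay, with a stated time of 48 h (on this read-out lower numbers stand for stronger inhibition of growth and higher numbers for weaker inhibition of growth), compound 1 (`CN1CCN(c2ccc(Nc3ncc(Cl)c(Nc4ccccc4)n3)nc2)CC1`) gives 37400 nM and compound 2 (`CN1CCN(c2ccc(Nc3ncc(Cl)c(Nc4ccc(C(C)(C)C)cc4)n3)nc2)CC1`) gives 16200 nM, the lower of the two numbers so far. Compound 3 (`Cc1cc(C)c(Nc2nc(Nc3ccc(N4CCN(C)CC4)cn3)ncc2Cl)c(C)c1`) is next, with 2,4,6-trimethylphenyl in place of 4-(tert-butyl)phenyl on a nitrogen on an aromatic ring.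

Among the measured compounds shown here, only one measured step bears on this change: a 2.3-fold lower number from compound 1 to compound 2 (0.36 log units; beyond the scatter). It is modest and comes from tert-butyl in place of hydrogen on an aromatic carbon. For the measured compounds named here, it gives only limited guidance, since the new change swaps one substituted phenyl for another and no measured compound carries the 2,4,6-trimethylphenyl group. With just this modest step from compound 2 as a guide, a large change in this assay is not expected. The expectation is no step beyond the scatter, with a slight lean towards a higher number. The expected step is a 1.4-fold higher number from compound 2 to compound 3 (0.13 log units; within the scatter). For compound 3 the estimated value is 22000 nM, with an expected range from 9000 nM to 55000 nM.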

Compound 3, concentration for 50% growth inhibition: 21000 nM
Beside the measured number, compound 3's estimate is 1.0-fold (0.02 log units) above it; low and high end bracket the measured number.
By their numbers in this assay, from the lowest: compounds 2, 3 and 1 (each within the scatter of the next, the first and the last beyond it).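

In this assay, 2,4,6-trimethylphenyl in place of 4-(tert-butyl)phenyl on the nitrogen gives a 1.3-fold higher number from compound 2 to compound 3 (0.11 log units; within the scatter), and 2,4,6-trimethylphenyl in place of phenyl at the same place gives a 1.8-fold lower number from compound 1 to compound 3 (0.25 log units; within the scatter). Compound 3 therefore cannot be separated from either compound 1 or compound 2, even though those two lie beyond the scatter of each other, so the new group adds a third all-carbon aromatic substituent at this nitrogen without establishing any new difference. Nothing available accounts for these small steps or shows how the substitution on the ring relates to growth inhibition.

Going by these compounds, all three groups at this place are aromatic rings of carbon only, so it remains open whether a ring bearing an amine or a carboxylic acid, or a pyridine ring in place of the phenyl ring, would give a step clearly beyond the scatter. On these data alone, the contribution of the rest of the shared core also stays open, including what a nitrile in place of the chlorine or a morpholine in place of the methylpiperazine would do to these numbers.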